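The source may hold more compounds than are shown below. What is called first, only, known or untested is meant among the compounds shown, and "the series" means these compounds.

In a functional assay on MCF7 cells (Homo sapiens) for cytotoxicity (on this read-out higher numbers stand for weaker inhibition and lower numbers for stronger inhibition), only one of the three measured compounds has a true number. Compound 1 (`Nc1ccc(-c2nc3c(O)cccc3s2)cc1`) reads > 100000 nM, which is a limit of the assay. Compound 3 (`Nc1ccc(-c2nc3ccccc3s2)cc1Cl`) reads < 1 nM, which is also a limit of the assay. For the measured compounds named here, compound 2 (`Nc1ccc(-c2nc3c(O)cccc3s2)cc1Cl`) gives 61400 nM, the only true number of the three.

Compound 4 (`CC(=O)Nc1ccc(-c2nc3c(O)cccc3s2)cc1Cl`) changes compound 2 at its amino group, which becomes acetamido: acetyl in place of hydrogen on a nitrogen on an aromatic ring. Going by the values given here, no measured step touches that nitrogen, so the evidence is indirect. The chloro step, an at least 1.6-fold lower number from compound 1 to compound 2 (0.21 log units; that floor lies within the scatter), has a floor within the scatter. The hydroxy step, an at least 61000-fold lower number from compound 2 to compound 3 (4.78 log units; beyond the scatter), is large and shows how far the read-out can move in this small set, but compound 4 keeps the hydroxy that this step removes. Nothing measured therefore points to a gain like that one, and no step beyond the scatter is expected in this assay. The expected change is a 1.0-fold lower number from compound 2 to compound 4 (0.01 log units; within the scatter). For compound 4 the estimate is 60000 nM, with an expected range from 20000 nM to 100000 nM.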

Compound 4, half-maximal inhibitory concentration: 56800 nM
Compound 4: middle estimate off by 1.1-fold (0.02 log units), on the high side; the range from low to high includes it.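

In this assay, this is the only step shown that touches the nitrogen on the aromatic ring, and acetyl in place of hydrogen there gives a 1.1-fold lower number from compound 2 to compound 4 (0.03 log units; within the scatter). With the hydroxy and the chloro kept in place, amino and acetamido therefore cannot be told apart on this read-out, so this change at this position leaves the number where the hydroxy-bearing compounds already sit, far from the gain seen when the hydroxy is absent. Nothing in the data shown offers an explanation for this flat result.

As far as these compounds go, whether the same change would be as silent without the hydroxy stays open, since the comparison would start from compound 3, which reads < 1 nM, a limit of the assay and not a number. Also open is how that nitrogen would respond to other groups, such as a longer acyl chain, a methylsulfonyl group or a carboxylic acid carried on a short chain, since acetyl is the only replacement for the hydrogen there among the compounds shown.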